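A few compounds are considered here, and "the series" means these few. Any claim that something is new, unique, unknown or untested is made for them only; others in the source may bear on it.

Compound 1 `CN(C)CCN1CCN(CC(=O)Nc2ccc(-c3nc4cc(F)ccc4o3)cc2)CC1` was tested in a functional assay on HT-29 cells (Homo sapiens) for cytotoxicity, read by MTT assay, with a stated time of 24 h (on this read-out lower numbers stand for stronger inhibition and higher numbers for weaker inhibition), where compound 1 gives 8190 nM. Its nearest comparison is compound 2 `Cc1cc(-c2nc3cc(F)ccc3o2)ccc1NC(=O)CN1CCN(CCN(C)C)CC1`, which in this assay gives 6600 nM; the two numbers lie within the scatter of each other, so neither can be called more potent. Among the compounds with values here, the one known step, a 1.2-fold lower number from compound 1 to compound 2 (0.09 log units; within the scatter), came from methyl in place of hydrogen on an aromatic carbon and did not move the number beyond the scatter. Compound 3 `CN(C)CCN1CCN(CC(=O)Nc2ccc(-c3nc4cc(Cl)ccc4o3)cc2)CC1` has not yet been measured. It differs from compound 1 by chloro in place of fluoro on an aromatic carbon, one halogen swapped for another at the same place on the fused system. Within the data shown here, no measured step involves this swap; the only guide is that the single change tried so far left this assay essentially unchanged. Compound 3 is therefore expected to show a 1.0-fold lower number from compound 1 to compound 3 (0.01 log units; within the scatter), nothing beyond the scatter. The estimate for compound 3 is 8000 nM, ranging from 3000 nM to 20000 nM.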

Compound 3, half-maximal inhibitory concentration: 4470 nM
Compound 3: the middle estimate sits 1.8-fold (0.25 log units) above what was measured; the measured number falls inside the stated range.
By their numbers in this assay, from the lowest: compounds 3, 2 and 1 (each within the scatter of the next).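

Within the data shown here, this is the first look at the halogen on the fused system: going from 5-fluoro-1,3-benzoxazol-2-yl to 5-chloro-1,3-benzoxazol-2-yl gives, in this assay, a 1.8-fold lower number from compound 1 to compound 3 (0.26 log units; within the scatter), so on this read-out the two halogens cannot be told apart at this place. Together with a 1.2-fold lower number from compound 1 to compound 2 (0.09 log units; within the scatter), it means that single changes at two different places on compound 1 have now both stayed within the scatter. Nothing available here bears on the reason for this result.

As far as these compounds go, what a bromo, methoxy or amino group at this same place would do remains open, as does whether any group there can move the number beyond the scatter. From the compounds shown here alone, it is also open whether chloro and the methyl of compound 2, combined in one molecule, would behave differently from either change alone.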